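The source may hold more compounds than are shown below. What is called first, only, known or untested is meant among the compounds shown, and "the series" means these compounds.

Measured compounds:
Compound 1 `COc1ccc(/C=C/C(=O)c2ccccc2-c2ccc(F)cc2)cc1` — 61 nM
Compound 2 `COc1ccc(/C=C/C(=O)c2ccccc2-c2ccc(F)cc2)cc1OC` — 570 nM
Compound 3 `COc1ccc(C(=O)/C=C/c2ccccc2-c2ccc(F)cc2)cc1` — 8400 nM

In a functional assay on SW480 cells (Homo sapiens) for antiproliferative activity, read by sulforhodamine B assay, with a stated time of 48 h (on this read-out lower numbers stand for stronger inhibition and higher numbers for weaker inhibition), compound 1 gives 61 nM. The change methoxy in place of hydrogen on an aromatic carbon gives a 9.3-fold higher number from compound 1 to compound 2 (0.97 log units; beyond the scatter). Compound 3 shares its atoms with compound 1 but joins them differently; the difference between the two cores is not broken down here. In this assay compound 3 gives 8400 nM, the highest number of the three.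

Compound 4 `COc1ccc(C(=O)/C=C/c2ccccc2-c2ccc(F)cc2)cc1OC` is not yet measured. It differs from compound 3 by methoxy in place of hydrogen on an aromatic carbon, the same change as from compound 1 to compound 2. Because that step was a 9.3-fold higher number from compound 1 to compound 2 (0.97 log units; beyond the scatter), a step of similar size is expected here, a 7.1-fold higher number from compound 3 to compound 4 (0.85 log units; beyond the scatter), resting on a single earlier instance only. Compound 4 is estimated at 60000 nM, between 15000 nM and 200000 nM.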

Compound 4, half-maximal inhibitory concentration: 8300 nM
Compound 4: middle estimate off by 7.2-fold (0.86 log units), on the high side, outside the stated range (below it).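

In this assay, methoxy in place of hydrogen on an aromatic carbon gives a 1.0-fold lower number from compound 3 to compound 4 (0.01 log units; within the scatter). The size of this step does not carry over between the two cores: the same change on two cores in this assay, a 9.3-fold higher number (0.97 log units; beyond the scatter) from compound 1 to compound 2 and a 1.0-fold lower number (0.01 log units; within the scatter) from compound 3 to compound 4, 9.5-fold (0.98 log units) apart, beyond the scatter of two such steps

The outcome of this change therefore depends on the core for this pair of cores, but the data do not show the reason, and one step on each core gives no rule for a third core. The compounds shown leave open how an amine, a hydroxyl or a carboxylic acid at this place would behave on either core. They also leave open whether a longer chain such as ethoxy would follow methoxy on each core.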